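A few compounds are considered here, and "the series" means these few. Any claim that something is new, unique, unknown or untested is made for them only; others in the source may bear on it.

Compound 2 `Cc1ccc(N2C(=O)[C@@H](n3cc(-c4ccccc4)nn3)[C@H]2/C=C/c2ccccc2)cc1` is one of three compounds tested in a functional assay on KB cells (Homo sapiens) for inhibition; a higher number here means a weaker inhibitor, a lower number a stronger inhibitor. In this assay compound 2 gives 89200 nM, and compound 1 `O=C1[C@@H](n2cc(-c3ccccc3)nn2)[C@@H](/C=C/c2ccccc2)N1c1ccccc1` gives 91300 nM; the two values sit within the scatter of each other. Compound 3 `COC(=O)c1nnn([C@@H]2C(=O)N(C3CCCCC3)[C@@H]2/C=C/c2ccccc2)c1C(=O)OC` is reported only as a limit of the assay, > 228000 nM. Within the data shown here, the single measured step between neighbours, a 1.0-fold lower number from compound 1 to compound 2 (0.01 log units; within the scatter), changed nothing beyond the scatter. Compound 4 `O=C1[C@@H](n2cc(-c3ccccc3)nn2)[C@@H](/C=C/c2ccccc2)N1c1ccc(Cl)cc1` differs from compound 2 by chloro in place of methyl on an aromatic carbon. Among the measured compounds shown here, no measured step involves a chloro group; the only guide is the step from compound 1 to compound 2, on an aromatic carbon, which stayed within the scatter. The expected step of a 1.0-fold higher number from compound 2 to compound 4 (0.00 log units; within the scatter) is therefore small, in no clear direction. Compound 4 is estimated at 90000 nM, with a range from 40000 nM to 200000 nM.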

Compound 4, half-maximal inhibitory concentration: 84200 nM
Beside the measured number, compound 4's estimate is 1.1-fold (0.03 log units) above it; measured number inside the range.
By their numbers in this assay, from the lowest: compounds 4, 2 and 1 (each within the scatter of the next). At a limit, above all of these: compound 3.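

In this assay chloro in place of methyl gives a 1.1-fold lower number from compound 2 to compound 4 (0.03 log units; within the scatter) and chloro in place of hydrogen gives a 1.1-fold lower number from compound 1 to compound 4 (0.04 log units; within the scatter) on the same aromatic carbon, para to a large group. This carbon has now carried hydrogen, methyl and chloro, and all three compounds lie within the scatter of one another. Nothing measured here bears on why these values stay so close. As far as these compounds go, whether an amine, a carboxylic acid or a methoxy group on this carbon would also stay within the scatter remains open.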